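The source may report more compounds than this note shows. Statements on the series, on what has been measured and on what is new or still open speak of the compounds shown alone.

In a functional assay on MOLT-4 cells (Homo sapiens) for cytotoxicity, read by CCK-8 assay, with a stated time of 24 h (on this read-out lower numbers stand for stronger inhibition and higher numbers for weaker inhibition), compound 1 `C=CC(=O)N1C(=O)CC(c2ccc(C(F)(F)F)cc2)Sc2ccccc21` gives 76300 nM, compound 2 `C=CC(=O)N1C(=O)CC(c2ccc(C)cc2)Sc2ccccc21` gives 87600 nM and compound 3 `C=CC(=O)N1C(=O)CC(c2ccc(OC)cc2)Sc2ccccc21` gives 83200 nM. Compound 3 therefore stands within the scatter of both other compounds. Compound 4 `C=CC(=O)N1C(=O)CC(C)Sc2ccccc21` carries a different kind of change: methyl in place of 4-methoxyphenyl on a saturated ring carbon. The measured steps are a 1.1-fold higher number from compound 1 to compound 2 (0.06 log units; within the scatter), a 1.1-fold higher number from compound 1 to compound 3 (0.04 log units; within the scatter) and a 1.1-fold lower number from compound 2 to compound 3 (0.02 log units; within the scatter). Each only swaps a group on an aromatic carbon, and none removes the aromatic ring, so they offer weak guidance. A modest move towards a higher number in this assay is expected, with much uncertainty. The expected change is a 1.3-fold higher number from compound 3 to compound 4 (0.12 log units; within the scatter). For compound 4 the estimated value is 110000 nM, with an expected range from 50000 nM to 250000 nM.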

Compound 4, half-maximal inhibitory concentration: 730000 nM
Compound 4: the middle estimate sits 6.6-fold (0.82 log units) below what was measured; measured number above the stated range.
By their numbers in this assay, from the lowest: compounds 1, 3 and 2 (each within the scatter of the next); then compound 4.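

At this saturated ring carbon next to the ring sulfur, replacing the aromatic group with methyl has a far larger effect than the earlier swaps on the aromatic ring, which all stayed within the scatter. In this assay methyl in place of 4-methoxyphenyl gives an 8.8-fold higher number from compound 3 to compound 4 (0.94 log units; beyond the scatter) and methyl in place of 4-methylphenyl gives an 8.3-fold higher number from compound 2 to compound 4 (0.92 log units; beyond the scatter) with both steps beyond the scatter and both towards weaker inhibition. The aromatic group at this position therefore goes with stronger inhibition than methyl does in these compounds. On these data alone, it remains open whether a longer chain such as butyl or a saturated cyclohexyl ring at this carbon would behave like methyl or like the aromatic groups. No measurement shown explains why the methyl compound is weaker.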